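Enlarging the methoxy group of compound 1

A few compounds are considered here, and "the series" means these few. Any claim that something is new, unique, unknown or untested is made for them only; others in the source may bear on it.

Going by the values given here, in a functional assay on MCF7 cells (Homo sapiens) for antiproliferative activity, read by MTT assay, with a stated time of 72 h (on this read-out lower numbers stand for stronger inhibition and higher numbers for weaker inhibition), compound 1 (`COc1ccc(-c2ncnn2-c2cc(OC)c(OC)c(OC)c2)cc1`) gives 360 nM as the only true number so far. Compound 2 (`COc1cccc(-c2ncnn2-c2cc(OC)c(OC)c(OC)c2)c1`) gives > 10000 nM and this value is a limit of the assay. Compound 1 thus holds the stronger place of just two compounds.

Compound 3 (`COc1cc(-n2ncnc2-c2ccc(OC(C)C)cc2)cc(OC)c1OC`) has not been measured and differs from compound 1 in one place. The difference is isopropyl in place of methyl on an oxygen on an aromatic ring and reads methoxy to isopropoxy.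

Among the compounds with values here, the one measured step that bears on this is an at least 27-fold higher number from compound 1 to compound 2 (1.44 log units; beyond the scatter) which is large and beyond the scatter. That step moves the methoxy group and does not enlarge it, so it is only indirect guidance. It shows that the number can respond sharply to a change at this group of compound 1. Within the data shown here, no measured step covers a larger group on that oxygen.

Expected on this basis is a 5.6-fold higher number from compound 1 to compound 3 (0.74 log units; beyond the scatter) as a moderate move towards weaker inhibition. Compound 3 is estimated in this assay at 2000 nM with an expected range from 300 nM to 10000 nM on this read-out.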

Compound 3, half-maximal inhibitory concentration: 610 nM
The estimate for compound 3 lay 3.3-fold (0.52 log units) above the measured number, within the range that was stated.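

In this assay, enlarging the group on this oxygen from methoxy to isopropoxy gives a 1.7-fold higher number from compound 1 to compound 3 (0.23 log units; within the scatter), so compound 1 and compound 3 cannot be told apart on this read-out. The earlier sharp response, an at least 27-fold higher number from compound 1 to compound 2 (1.44 log units; beyond the scatter), came from moving the methoxy group and therefore does not carry over to enlarging it where it stands in compound 1; at this place on the shared core, isopropyl can replace methyl with no change beyond the usual scatter. Only compound 2 sits at a limit of the assay, which leaves the comparison of compound 1 with compound 3 as one between two true numbers: the limit of > 10000 nM in this assay, at which 1 of the 3 values shown sits.

How far this position accepts larger groups remains open, since isopropyl is the largest group shown on this oxygen, and a longer chain such as butyl, a ring such as cyclopentyl or a polar end such as an amine could give a different result. Also open, from the compounds shown here alone, is what a hydrogen on this oxygen would do, leaving a free hydroxyl, and whether isopropoxy would fare any better than methoxy in the placement of compound 2.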